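A few compounds are considered here, and "the series" means these few. Any claim that something is new, unique, unknown or untested is made for them only; others in the source may bear on it.

Values in a functional assay on CCRF-CEM cells (Homo sapiens), read by MTT assay, with a stated time of 72 h; on this read-out higher numbers stand for weaker inhibition and lower numbers for stronger inhibition:

- compound 1 `CN(C)c1ncnc2c1c(-c1cc3ccccc3o1)cn2[C@@H]1O[C@H](CO)[C@@H](O)[C@H]1O` gives > 20000 nM (a limit)
- compound 2 `C#Cc1cn([C@@H]2O[C@H](CO)[C@@H](O)[C@H]2O)c2ncnc(N(C)C)c12` gives 90 nM
- compound 3 `Nc1nc(N)c2c(-c3ccco3)cn([C@@H]3O[C@H](CO)[C@@H](O)[C@H]3O)c2n1` gives > 20000 nM (a limit)

Compound 3 gives > 20000 nM as a limit and not a number. Alongside compound 1, it sits at the limit of > 20000 nM in this assay, at which 2 of the 3 values shown sit, in this series, so its true position is unknown.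

Compound 4 `Nc1nc(N)c2c(-c3ccsc3)cn([C@@H]3O[C@H](CO)[C@@H](O)[C@H]3O)c2n1` differs from compound 3 by one group: thiophen-3-yl in place of furan-2-yl on an aromatic carbon. One five-membered aromatic ring with 1 hetero atom thus replaces another.

Within the data shown here, the only measured step is an at least 220-fold lower number from compound 1 to compound 2 (2.34 log units; beyond the scatter) with ethynyl in place of 1-benzofuran-2-yl on an aromatic carbon. It is large, so a swap of this kind can matter on the core of compound 1. It bears only loosely here, since it removes an aromatic ring system and belongs to a different core.

The change to compound 4 keeps a five-membered aromatic ring in place, and the closest reference is compound 3 with its > 20000 nM limit. No step beyond the scatter is therefore expected in this assay, and the expected step is a number no higher from compound 3 to compound 4 (the limit leaves the size open) with either direction open. For compound 4 the estimate is 20000 nM with an expected range from 4000 nM to 50000 nM and a report as a limit is the likeliest outcome.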

Compound 4, half-maximal inhibitory concentration: > 20000 nM
Compound 4 gave a limit, no number (the forecaster's own chance of this, stated with the estimate: 70%); the middle value sits exactly at the limit.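

No new step can be read: in this assay, compound 3 and compound 4 both stand as limits, so the change from furan-2-yl to thiophen-3-yl has no readable size. Most of the series now sits at one limit: the limit of > 20000 nM in this assay, at which 3 of the 4 values shown sit.

The compounds shown leave open whether either ring on this shared core gives a measurable value in this assay.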